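Shifting a Hydroxyl Group: Two Analogous Steps Compared

The source may report more compounds than this note shows. Statements on the series, on what has been measured and on what is new or still open speak of the compounds shown alone.

Compound 1 `Oc1cccc(-c2cc(-c3ccco3)cc(-c3ccccc3O)n2)c1` carries two hydroxyphenyl groups and a furan-2-yl group on a shared core. In a functional assay on DU-145 cells (Homo sapiens) for cytotoxicity, read by CCK-8 assay (a higher number here means a weaker inhibitor, a lower number a stronger inhibitor), compound 1 gives 1790 nM. Compound 2 `Oc1ccc(-c2cc(-c3ccco3)cc(-c3ccccc3O)n2)cc1` differs in one place: 4-hydroxyphenyl in place of 3-hydroxyphenyl on an aromatic carbon. In this assay compound 2 reaches only > 50000 nM, which is a limit of the assay and not a number. The resulting step is an at least 27-fold higher number from compound 1 to compound 2 (1.44 log units; beyond the scatter), and its size is known only as a lower bound because of the limit of > 50000 nM in this assay, at which 1 of the 3 values shown sits.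

Compound 3 `Oc1cccc(-c2cc(-c3ccccn3)cc(-c3cccc(O)c3)n2)c1` has a different core; how it differs from compound 1 is not broken down here. In this assay compound 3 gives 3610 nM, a value that lies within the usual scatter of compound 1.

Compound 4 `Oc1ccc(-c2cc(-c3ccccn3)cc(-c3cccc(O)c3)n2)cc1` is not yet measured and differs from compound 3 in one place: 4-hydroxyphenyl in place of 3-hydroxyphenyl on an aromatic carbon. This is the same kind of change as that from compound 1 to compound 2, at the same place next to the ring nitrogen, but the surroundings differ: in compound 1 the place is meta to a 2-hydroxyphenyl group and meta to a furan-2-yl group, in compound 3 it is meta to a 3-hydroxyphenyl group and meta to a pyridin-2-yl group.

The step of a 17-fold higher number from compound 3 to compound 4 (1.22 log units; beyond the scatter) is expected to be large and upward, resting on an at least 27-fold higher number from compound 1 to compound 2 (1.44 log units; beyond the scatter) measured for compound 1. Compound 4 is therefore estimated at 60000 nM, between 10000 nM and 200000 nM.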

Compound 4, half-maximal inhibitory concentration: 1980 nM
Compound 4: the middle estimate sits 30-fold (1.48 log units) above what was measured; measured number below the stated range.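

In this assay, 4-hydroxyphenyl in place of 3-hydroxyphenyl gives a 1.8-fold lower number from compound 3 to compound 4 (0.26 log units; within the scatter), so on this core the swap produces no real difference. The large step seen on the core of compound 1 therefore did not carry over to the core of compound 3, and the two results clearly disagree: the same change on two cores in this assay, an at least 27-fold higher number (1.44 log units; beyond the scatter) from compound 1 to compound 2 and a 1.8-fold lower number (0.26 log units; within the scatter) from compound 3 to compound 4, at least 50-fold (1.70 log units) apart, beyond the scatter of two such steps This shows that the same change cannot be assumed to have the same result on both cores, but it does not show which difference between them matters, for compound 1 has a furan-2-yl and a 2-hydroxyphenyl group where compound 3 has a pyridin-2-yl and a 3-hydroxyphenyl group, and these two differences cannot be told apart here.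

Going by these compounds, it remains open which of these two groups decides whether the swap has a large result, a question that a core differing from compound 1 in only one of them could answer. On these data alone, it also remains open whether the hydroxyl itself matters on the phenyl ring that was changed, which a methoxy group, an amine or a carboxylic acid in its place could test.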